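The source may report more compounds than this note shows. Statements on the series, on what has been measured and on what is new or still open speak of the compounds shown alone.

Of the compounds shown here, two have been measured in an assay on cells for inhibition of S-adenosylmethionine decarboxylase proenzyme (Homo sapiens), read by mass spectrometry, at pH 7.2, tested at 180 uM (a higher number here means more inhibition at the concentration tested (going by the name of the read-out), a lower number less inhibition), so far. Compound 2 `C=CCOc1cc(Br)cc(Nc2cc(C)nc(N)n2)c1` gives 28%, and compound 1 `CCOc1cc(Br)cc(Nc2cc(C)nc(N)n2)c1` gives 36%; the step of a number 8 percentage points lower from compound 1 to compound 2 (within the scatter) keeps the two within the scatter, so neither number can be called the higher. Compound 3 `Cc1cc(Nc2cc(Br)cc(Br)c2)nc(N)n1` differs from compound 2 by bromo in place of allyloxy on an aromatic carbon. Among the measured compounds shown here, the one measured step, from compound 1 to compound 2, swapped one small chain on the oxygen for another and left the oxygen in place, whereas here the whole allyloxy group is removed and a bromo takes its seat on the ring. For the measured compounds named here, no measured step covers such a change, so the only guide is that the lone step seen was within the scatter. Compound 3 is therefore expected to land near compound 2, with a step of about a number 2 percentage points higher from compound 2 to compound 3 (within the scatter), and its estimated inhibition is 30%, most likely between 5% and 60%.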

Compound 3, a percentage reported as inhibition, at one concentration (the size of the read-out at that concentration, not a potency): 31%
Estimate against measurement, compound 3: 1 percentage points below; the range from low to high includes it.
By their numbers in this assay, from the lowest: compounds 2, 3 and 1 (each within the scatter of the next).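

In this assay, replacing the allyloxy group with a bromo gives a number 3 percentage points higher from compound 2 to compound 3 (within the scatter), and replacing the ethoxy group with a bromo gives a number 5 percentage points lower from compound 1 to compound 3 (within the scatter). The earlier compounds shown here changed only the chain and kept the oxygen on the ring, whereas these steps show that on this aromatic carbon the whole group, oxygen included, can give way to a single bromine atom without a step beyond the scatter. Nothing available here accounts for how close these numbers lie.

Going by these compounds, what stays open is whether any group at this position can move the number beyond the scatter, for example an amine, a carboxylic acid or a longer chain. These readings at one concentration also leave open how the three compounds compare in potency.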